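Replacing 2-fluorophenyl with 2,4-dichlorophenyl on the carbonyl

The source may hold more compounds than are shown below. What is called first, only, known or untested is meant among the compounds shown, and "the series" means these compounds.

Of the compounds shown here, three sharing one core have been measured in a functional assay on HeLa cells (Homo sapiens) for inhibition, read by MTT assay, with a stated time of 72 h; on this read-out higher numbers stand for weaker inhibition and lower numbers for stronger inhibition. Compound 1 `CN(C(=O)NC(=O)c1cccc(C(F)(F)F)c1)c1nc(C(F)(F)F)c(C(=O)N/N=C/c2cccc(C(F)(F)F)c2)s1` gives 4.81 ug/mL. Compound 2 `CN(C(=O)NC(=O)c1ccc(Cl)cc1Cl)c1nc(C(F)(F)F)c(C(=O)N/N=C/c2ccc(C(F)(F)F)cc2)s1` gives 7.99 ug/mL. Compound 3 `CN(C(=O)NC(=O)c1ccccc1F)c1nc(C(F)(F)F)c(C(=O)N/N=C/c2cccc(C(F)(F)F)c2)s1` gives 19.1 ug/mL, the highest of the three numbers; its nearest neighbour is compound 2, and compound 1 lies furthest from it, both gaps being beyond the scatter.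

Compound 4 `CN(C(=O)NC(=O)c1ccc(Cl)cc1Cl)c1nc(C(F)(F)F)c(C(=O)N/N=C/c2cccc(C(F)(F)F)c2)s1` has not yet been measured in this assay. It differs from compound 3 in one place: 2,4-dichlorophenyl in place of 2-fluorophenyl on a carbonyl carbon.

Within the data shown here, one measured step bears on this change. The step of a 4.0-fold higher number from compound 1 to compound 3 (0.60 log units; beyond the scatter) shows that the 2-fluorophenyl group on the carbonyl carbon goes with a higher number than a 3-(trifluoromethyl)phenyl group there. Compound 4 shares the 2,4-dichlorophenyl group on the carbonyl carbon with compound 2 but differs from it in the hydrazone part; in this assay compound 2 gives 7.99 ug/mL. Among the measured compounds shown here, no step between compound 2 and compound 4 is computed here, so only the two values can be set side by side.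

Taken together, a move away from 2-fluorophenyl is expected to lower the number in this assay by a modest amount, estimated as a 2.9-fold lower number from compound 3 to compound 4 (0.47 log units; beyond the scatter). Compound 4 is therefore expected to give about 6.5 ug/mL, within a range from 3 ug/mL to 14 ug/mL.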

Compound 4, half-maximal inhibitory concentration: 9.6 ug/mL
Estimate against measurement, compound 4: 1.5-fold (0.17 log units) below; low and high end bracket the measured number.
By their numbers in this assay, from the lowest: compounds 1, 2, 4 and 3 (each within the scatter of the next, the first and the last beyond it).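

In this assay, 2,4-dichlorophenyl on the carbonyl carbon cannot be told apart from 2-fluorophenyl (a 2.0-fold lower number from compound 3 to compound 4 (0.30 log units; within the scatter)), nor from 3-(trifluoromethyl)phenyl (a 2.0-fold higher number from compound 1 to compound 4 (0.30 log units; within the scatter)), so this position now holds a third group that lies within the scatter of both groups whose step had stood beyond it. Among these compounds, at the other end of the molecule, with 2,4-dichlorophenyl on the carbonyl carbon, 3-(trifluoromethyl)phenyl in place of 4-(trifluoromethyl)phenyl on a carbon with a double bond to nitrogen gives no readable difference (a 1.2-fold higher number from compound 2 to compound 4 (0.08 log units; within the scatter)), the first view of a change at that place. Nothing at hand accounts for how these groups compare.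

Every group shown on the carbonyl carbon is a substituted phenyl, so it remains open how an unsubstituted phenyl, a pyridine, a plain alkyl chain or a phenyl carrying an amine or a carboxylic acid would read there. Going by these compounds, it also remains open whether the gap between 2-fluorophenyl and 3-(trifluoromethyl)phenyl on the carbonyl carbon would hold with 4-(trifluoromethyl)phenyl on the carbon with a double bond to nitrogen.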